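This account rests on a few compounds, and the source may have more. Where it says the series, first, only, none or still open, it means among the compounds named here.

Compound 3, `Cn1ncc2c(=O)n(-c3ccccc3)c(SCc3cccc(F)c3)nc21`, gives 3% in an assay on PEO1 cells for inhibition of Retinaldehyde dehydrogenase 3 (Homo sapiens), read by flow cytometry, with a stated time of 30 min, tested at 1 uM (on this read-out lower numbers stand for less inhibition and higher numbers for more inhibition at the one concentration tested (going by the name of the read-out)), the lowest of the three numbers recorded there. Its nearest neighbour is compound 2, `CC(Sc1nc2c(cnn2C)c(=O)n1-c1ccccc1)c1ccccc1`, which gives 47%; furthest away is compound 1, `CC(Sc1nc2c(cnn2C)c(=O)n1-c1ccccc1)c1ccccn1`, which gives 97%. Both gaps are beyond the scatter.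

Compound 4, `CC(Sc1nc2c(cnn2C)c(=O)n1-c1ccccc1)c1cccc(O)c1`, has not yet been measured. It differs from compound 3 in one place: a group of 9 heavy atoms (8 carbon, 1 oxygen; one six-membered aromatic ring of carbon only) in place of a group of 8 heavy atoms (7 carbon, 1 fluorine; one six-membered aromatic ring of carbon only), on a sulfur. The entering group carries one hydrogen-bond donor and one hydrogen-bond acceptor, where the leaving 3-fluorobenzyl carried none.

Within the data shown here, two measured steps bear on this change. The step of a number 44 percentage points lower from compound 2 to compound 3 (beyond the scatter) shows that replacing a 1-phenylethyl on the sulfur with 3-fluorobenzyl cost a large amount of inhibition, and the step of a number 94 percentage points lower from compound 1 to compound 3 (beyond the scatter) shows an even larger loss from 1-(pyridin-2-yl)ethyl. Among the measured compounds shown here, compound 4 restores a group of the 1-arylethyl kind on the sulfur, so an increase beyond the scatter is expected, of a size close to the reverse of the step from compound 2 to compound 3, though the oxygen on the ring has no measured precedent here. Compound 4 is therefore expected to give 40%, within 10% to 75%, an estimated step of a number 37 percentage points higher from compound 3 to compound 4 (beyond the scatter).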

Compound 4, a percentage reported as inhibition, at one concentration (the size of the read-out at that concentration, not a potency): 61%
Compound 4: middle estimate off by 21 percentage points, on the low side, and the stated range covers the measured number.
By their numbers in this assay, from the lowest: compound 3; then compound 2; then compound 4; then compound 1.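

On the 1-phenylethyl group, hydroxy in place of hydrogen on an aromatic carbon gives a number 14 percentage points higher from compound 2 to compound 4 (beyond the scatter) in this assay, so this ring accepts a hydroxy and the number rises modestly rather than falling. The full exchange on the sulfur gives a number 58 percentage points higher from compound 3 to compound 4 (beyond the scatter) and so goes further than undoing the fall of a number 44 percentage points lower from compound 2 to compound 3 (beyond the scatter), which shows that the gain over the 3-fluorobenzyl compound is not limited to what the unsubstituted 1-phenylethyl group recovers. The hydroxy still does not close the gap to the pyridin-2-yl group, as a number 36 percentage points lower from compound 1 to compound 4 (beyond the scatter) shows, and compound 1 remains the highest of the four, with its steps to all the others beyond the scatter.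

No evidence shown accounts for any of these steps. From the compounds shown here alone, it remains open whether a methoxy or an amine on the same aromatic ring would give a similar rise, and whether a hydroxy added to the pyridin-2-yl ring of compound 1 would change its number at all.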